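Compound 4 against compound 2: working notes

The source may report more compounds than this note shows. Statements on the series, on what has been measured and on what is new or still open speak of the compounds shown alone.

In a functional assay, read by fluorescence and spectrophotometry, with a stated time of 1 h (a higher number here means that more compound is needed for the effect, a lower number that less compound is needed), compound 2 `O=S(=O)(/C=C/c1ccc(O)c(O)c1)CCCCCCCO` gives 5900 nM and is not separated from compound 1 `O=S(=O)(/C=C/c1ccc(O)c(O)c1)CC1CCC1` at 8800 nM or compound 3 `O=S(=O)(/C=C/c1ccc(O)c(O)c1)CC1CCCO1` at 10500 nM by more than the scatter. The steps of a 1.5-fold lower number from compound 1 to compound 2 (0.17 log units; within the scatter) and a 1.8-fold higher number from compound 2 to compound 3 (0.25 log units; within the scatter) and a 1.2-fold higher number from compound 1 to compound 3 (0.08 log units; within the scatter) exchanged cyclobutyl, 6-hydroxyhexyl and oxolan-2-yl, and all stayed within the scatter. The change phenyl in place of 4-hydroxybutyl on a saturated chain carbon, three bonds along the chain from a sulfonyl sulfur gives compound 4 `O=S(=O)(/C=C/c1ccc(O)c(O)c1)CCCc1ccccc1` with phenyl in place of 4-hydroxybutyl on a saturated chain carbon, three bonds along the chain from a sulfonyl sulfur. Within the data shown here, no measured step brings in an aromatic ring, so no direction can be argued. The expected step of a 1.0-fold higher number from compound 2 to compound 4 (0.01 log units; within the scatter) in this assay is therefore none beyond the scatter. For compound 4 the estimated value is 6000 nM with an expected range from 2500 nM to 12000 nM in this measurement.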

Compound 4, half-maximal effective concentration: 11500 nM
Compound 4: middle estimate off by 1.9-fold (0.28 log units), on the low side; the range from low to high includes it.
By their numbers in this assay, from the lowest: compounds 2, 1, 3 and 4 (each within the scatter of the next).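

Phenyl in place of 4-hydroxybutyl, on a saturated chain carbon, three bonds along the chain from a sulfonyl sulfur, is the first step in the series to bring in an aromatic ring; in this assay it gives a 1.9-fold higher number from compound 2 to compound 4 (0.29 log units; within the scatter) and stays within the scatter. This position therefore accepts an all-carbon aromatic ring in place of the hydroxyl-bearing chain without a step beyond the scatter. No evidence is available on what lies behind this step.

On these data alone, whether an amine or a carboxylic acid at this position would give a step beyond the scatter remains open. Also open, as far as these compounds go, is whether a methoxy group on the phenyl ring of compound 4 would do so.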